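The source may report more compounds than this note shows. Statements on the series, on what has been measured and on what is new or still open speak of the compounds shown alone.

For the measured compounds named here, in a functional assay on SW-620 cells (Homo sapiens) for cytotoxicity, read by MTT assay, with stated times of 4 h and 72 h, tested at 5 uM (on this read-out higher numbers stand for weaker inhibition and lower numbers for stronger inhibition), compound 2 `Cc1cc(Nc2ccc(C(=O)/C=C/c3ccc4ccccc4c3)cc2)n2nc(SCc3ccccc3)nc2n1` gives 300 nM, the lower of the two numbers measured so far, while compound 1 `Cc1ccc(CSc2nc3nc(C)cc(Nc4ccc(C(=O)/C=C/c5ccc6ccccc6c5)cc4)n3n2)cc1` gives 880 nM. Compound 3 `Cc1cc(Nc2ccc(C(=O)/C=C/c3ccc4ccccc4c3)cc2)n2nc(SCc3cccc([N+](=O)[O-])c3)nc2n1` carries one change to compound 2, nitro in place of hydrogen on an aromatic carbon, which turns benzyl into 3-nitrobenzyl: nitro in place of hydrogen on an aromatic carbon. Going by the values given here, only one measured step bears on this, a 2.9-fold lower number from compound 1 to compound 2 (0.47 log units; beyond the scatter), a modest step in which hydrogen replaces methyl on an aromatic carbon. Among the compounds with values here, there, the compound with the added group has the higher number, but methyl is not nitro, and no measurement yet shows what nitro does. A modest move toward a higher number in this assay is therefore expected, though with little confidence, and the expected step is a 1.7-fold higher number from compound 2 to compound 3 (0.22 log units; within the scatter). The estimate for compound 3 is 500 nM, within a range of 150 nM to 1600 nM.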

Compound 3, half-maximal inhibitory concentration: 790 nM
Beside the measured number, compound 3's estimate is 1.6-fold (0.20 log units) below it; the measured number falls inside the stated range.
By their numbers in this assay, from the lowest: compound 2; then compounds 3 and 1 (each within the scatter of the next).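

In this assay, placing nitro on the benzyl ring of compound 2 gives a 2.6-fold higher number from compound 2 to compound 3 (0.42 log units; beyond the scatter), so a second group on this ring, chemically unlike methyl, also goes with a higher number than plain benzyl. The two substituted compounds then show a 1.1-fold lower number from compound 1 to compound 3 (0.05 log units; within the scatter), which means that 3-nitrophenyl and 4-methylphenyl cannot be told apart here, and among these three compounds only the unsubstituted ring stands apart. Nothing measured here offers a reason for this shift. 

From the compounds shown here alone, with only methyl and nitro, at different places on the ring, it stays open whether the particular group matters or whether almost any addition to this ring raises the number. An amine or a carboxylic acid on this ring, or a longer chain between the sulfur and the ring, remains an open case.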